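The source may hold more compounds than are shown below. What is called first, only, known or untested is meant among the compounds shown, and "the series" means these compounds.

Compounds measured in a functional assay on HepG2 cells (Homo sapiens) for antiproliferative activity, read by MTT assay, with a stated time of 72 h; on this read-out lower numbers stand for stronger inhibition and higher numbers for weaker inhibition:
- Compound 1 `O=C1COc2ccc(-c3cccc(NS(=O)(=O)c4ccc(F)cc4)c3)cc2N1`: > 40000 nM (a limit, not a number)
- Compound 2 `CC(C)N1C(=O)COc2ccc(-c3cnc(Cl)c(NS(=O)(=O)c4ccc(F)cc4)c3)cc21`: 21500 nM
- Compound 3 `CC(C)N1C(=O)COc2ccc(-c3cccc(NS(=O)(=O)c4ccc(F)cc4)c3)cc21`: > 40000 nM (a limit, not a number)

For the measured compounds named here, compound 2 is the only compound here with a true number, 21500 nM. Apart from it there is only (the limit of > 40000 nM in this assay, at which 2 of the 3 values shown sit).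

Compound 4 `O=C1COc2ccc(-c3cnc(Cl)c(NS(=O)(=O)c4ccc(F)cc4)c3)cc2N1C1CC1` differs from compound 2 in one place: cyclopropyl in place of isopropyl on an amide-type nitrogen in a ring. Cyclopropyl takes the place of isopropyl on an amide-type nitrogen in a ring, so the three carbons of the group now form a three-membered ring.

Going by the values given here, the only measured change at this nitrogen is a step that the two limits leave unreadable from compound 1 to compound 3, with isopropyl in place of hydrogen. Among the compounds with values here, both of its ends are limits, so it offers no size to carry over, and no measured compound here carries cyclopropyl. The expectation therefore rests on compound 2 with 21500 nM, and no shift beyond the usual scatter is expected in this assay, in either direction. The expected change is a 1.1-fold lower number from compound 2 to compound 4 (0.03 log units; within the scatter). With so little evidence, the range has to stay wide, and a result at the limit of the assay remains possible. Compound 4 is estimated at 20000 nM, with an expected range from 8000 nM to 40000 nM.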

Compound 4, half-maximal inhibitory concentration: 8510 nM
Estimate against measurement, compound 4: 2.4-fold (0.37 log units) above; the measured number falls inside the stated range.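

In this assay, putting cyclopropyl in place of isopropyl on the amide-type nitrogen gives a 2.5-fold lower number from compound 2 to compound 4 (0.40 log units; beyond the scatter). Both groups have 3 heavy atoms, all carbon, so joining those carbons into a three-membered ring is enough to move the number, although the step is only modest and comes from a single pair of compounds. This is also the first change at this nitrogen whose size can be read, since the other change there cannot be read, with a limit at both of its ends: the limit of > 40000 nM in this assay, at which 2 of the 4 values shown sit.

The compounds shown leave open whether the lower number belongs to the three-membered ring itself, or whether a cyclobutyl ring or a longer chain such as n-propyl on this nitrogen would give a similar result. They also do not explain why cyclopropyl gives the lower number, or show whether the same swap would have a similar effect on the core of compound 3.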